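Dihalophenyl for methylphenyl on the shared core

The compounds below may be only part of what the source reports. "The series", "measured", "known", "first", "only" and "open" are said of these compounds alone.

Measured so far in a functional assay on U-937 cells (Homo sapiens) for cytotoxicity, read by CCK-8 assay, with a stated time of 72 h; a higher number here means a weaker inhibitor, a lower number a stronger inhibitor:
Compound 1, `C=CCn1c(=O)/c(=C\c2cccc(C)c2)[nH]c(=O)/c1=C\c1ccccc1OC`: 5100 nM
Compound 3, `COc1ccccc1/C=c1\c(=O)[nH]/c(=C/c2ccccc2Cl)c(=O)n1C`: 100 nM
Compound 2, `C=CCn1c(=O)/c(=C\c2ccc(Cl)c(Cl)c2)[nH]c(=O)/c1=C\c1ccccc1`: "not active" (no number reported), reported without a number.

Compound 1 holds the higher of the two numbers; compound 3 sits lower by a gap beyond the scatter, and compound 2 stands apart without a value. Compound 4, `C=CCn1c(=O)/c(=C\c2ccc(F)c(Br)c2)[nH]c(=O)/c1=C\c1ccccc1OC`, keeps the core of compound 1 and differs in one place: 3-bromo-4-fluorophenyl in place of 3-methylphenyl on a double-bonded chain carbon bound to an aromatic carbon. Within the data shown here, no measured pair isolates this change. Compound 2 also carries two halogens on one aryl group and gives "not active" (no number reported) in this assay, so a weaker or unchanged result is expected rather than a gain. Compound 4 is estimated at 9000 nM, range 2500 nM to 35000 nM, the expected step being a 1.8-fold higher number from compound 1 to compound 4 (0.25 log units; within the scatter).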

Compound 4, half-maximal inhibitory concentration: "not active" (no number reported)
Compound 4: no number reported, and the estimate cannot be compared.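

Among these compounds, compound 4 reports no number in this assay, so no step from compound 1 to compound 4 can be read. The compounds shown leave open how 3-bromo-4-fluorophenyl in place of 3-methylphenyl shifts the number on the shared core. No measured evidence bears on this result.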